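A few compounds are considered here, and "the series" means these few. Any claim that something is new, unique, unknown or untested is made for them only; others in the source may bear on it.

Measured compounds in this series:
compound 1 `Cc1ccc(C2CNC(=O)N2S(=O)(=O)c2ccc3c(c2)CCC3)cc1`: 88600 nM
compound 2 `Cc1ccc(C2CNC(=O)N2S(=O)(=O)c2ccc(Cl)cc2)cc1`: 255000 nM
compound 3 `O=C1NCC(c2ccccc2)N1S(=O)(=O)c1ccc2c(c1)CCC2`: 39000 nM

In a functional assay on SK-MEL-2 cells (Homo sapiens) for cytotoxicity (on this read-out lower numbers stand for stronger inhibition and higher numbers for weaker inhibition), compound 3 stands lowest of the three numbers, with compound 1 nearest and compound 2 furthest above it. Compound 4 `O=C1NCC(c2ccc(Br)cc2)N1S(=O)(=O)c1ccc2c(c1)CCC2` has not been measured yet; it differs from compound 3 by bromo in place of hydrogen on an aromatic carbon. Among the compounds with values here, the only step that touches the same aromatic carbon is a 2.3-fold lower number from compound 1 to compound 3 (0.36 log units; beyond the scatter), where a group leaves that carbon and the number falls. Within the data shown here, compound 4 instead places a group onto it, and no measured step carries a bromo group, so the chemist has one indirect comparison to go on. She expects a modest rise in this assay, a 1.5-fold higher number from compound 3 to compound 4 (0.19 log units; within the scatter), and estimates compound 4 at 60000 nM, with a range from 20000 nM to 180000 nM.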

Compound 4, half-maximal inhibitory concentration: 119000 nM
Compound 4: the middle estimate sits 2.0-fold (0.30 log units) below what was measured, and the stated range covers the measured number.
By their numbers in this assay, from the lowest: compound 3; then compounds 1 and 4 (each within the scatter of the next); then compound 2.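

In this assay, the change from phenyl to 4-bromophenyl gives a 3.1-fold higher number from compound 3 to compound 4 (0.48 log units; beyond the scatter), so across compounds 1, 3 and 4, hydrogen on this aromatic carbon has the lowest number, whichever of the two groups replaces it. Bromo and methyl at this carbon cannot be told apart, with a 1.3-fold higher number from compound 1 to compound 4 (0.13 log units; within the scatter). Nothing shown here explains the rise that either group brings.

From the compounds shown here alone, it remains open whether an amine, a methoxy group or a carboxylic acid on this carbon would also raise the number. Going by these compounds, it is also open whether the step from hydrogen to bromo holds with another group on the sulfonyl side.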